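The source may report more compounds than this note shows. Statements on the series, on what has been measured and on what is new or still open speak of the compounds shown alone.

Within this small set, compound 3, with structure `CC(C)(C)CC[C@H](c1ccc(C(=O)NCCCC(=O)O)cc1)N1C(=O)C(c2cc(Cl)cc(Cl)c2)=N[C@]12CC[C@@H](C(C)(C)C)CC2`, stands at the weak end: in an assay on CHO cells for displacement of a labelled ligand from Glucagon receptor (Homo sapiens), read by scintillation counting, with a stated time of 60 min (on this read-out higher numbers stand for weaker inhibition and lower numbers for stronger inhibition), compound 3 gives 270 nM, the highest of the three numbers. Compound 1, `CC[C@H]1CC[C@]2(CC1)N=C(c1cc(Cl)cc(Cl)c1)C(=O)N2[C@H](CCC(C)(C)C)c1ccc(C(=O)NCc2nn[nH]n2)cc1`, gives 44 nM in this assay, and compound 2, `CC(C)(C)CC[C@H](c1ccc(C(=O)NCc2nn[nH]n2)cc1)N1C(=O)C(c2ccc(F)cc2)=N[C@]12CC[C@@H](C(C)(C)C)CC2`, gives 13 nM; both of those carry a tetrazole-bearing amide side chain rather than the carboxylic acid chain of compound 3, and both lie beyond the scatter from it. Compound 4, `CC(C)(C)CC[C@H](c1ccc(C(=O)NCCC2=NNNN2)cc1)N1C(=O)C(c2cc(Cl)cc(Cl)c2)=N[C@]12CC[C@@H](C(C)(C)C)CC2`, differs from compound 3 in one place: a group of 5 heavy atoms (1 carbon, 4 nitrogen; one five-membered non-aromatic ring with 4 hetero atoms) in place of a group of 4 heavy atoms (2 carbon, 2 oxygen; no ring), on a saturated chain carbon, two bonds along the chain from an amide-type nitrogen. Going by the values given here, no measured pair in this set shares exactly that change, so the expectation rests on the observation that the two tetrazole-bearing compounds, compound 1 and compound 2, sit well below compound 3 in this assay. A step downward, beyond the scatter, is therefore expected from compound 3 to compound 4, of about a 4.5-fold lower number from compound 3 to compound 4 (0.65 log units; beyond the scatter). Compound 4 is estimated at 60 nM in this assay, within a range from 20 nM to 200 nM.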

Compound 4, half-maximal inhibitory concentration: 65 nM
Compound 4: the middle estimate sits 1.1-fold (0.03 log units) below what was measured, within the range that was stated.
By their numbers in this assay, from the lowest: compound 2; then compounds 1 and 4 (each within the scatter of the next); then compound 3.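

Compounds 1, 2 and 3 differ from one another in more than one place, so they could not separate the side-chain end from the rest of the structure. In this assay the change alone, on a saturated chain carbon, two bonds along the chain from an amide-type nitrogen, gives a 4.2-fold lower number from compound 3 to compound 4 (0.62 log units; beyond the scatter) with the rest of the molecule held constant. This shows that the end of the chain on its own moves the number by a modest step, and that a five-membered non-aromatic ring with 4 hetero atoms is accepted there in place of carboxymethyl, although nothing given here accounts for the step. Going by these compounds, whether the same change gives a similar step on the cores of compound 1 or compound 2 remains open. So does how a primary amide, an amine or a longer chain would read at this place.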